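The compounds below may be only part of what the source reports. "The series", "measured", "known", "first", "only" and "open" are said of these compounds alone.

Working notes on a series tested in an assay on isolated protein for inhibition of Leucine-rich repeat serine/threonine-protein kinase 2 variant G2019S (Homo sapiens), read by TR-FRET and LanthaScreen, with stated times of 50 min and 30 min, in the presence of a further agent that is not named here; on this read-out higher numbers stand for weaker inhibition and lower numbers for stronger inhibition. Compound 1 `CN(C)c1c(C#N)c2c(N)ncnc2n1C` gives 3760 nM. Compound 2 `Cc1nn(CC(C)(C)O)cc1Nc1nc(N)c2c(C#N)c(N3CCC[C@H]3C)n(C)c2n1` gives 42 nM, and compound 3 `Cc1c(Nc2nc(N)c3c(C#N)c(N4CCC[C@H]4C)n(C)c3n2)cnn1[C@@H]1CCOC1` gives 12 nM. On these numbers compound 2 stands second highest of the three, with the gap to compound 3 and the much larger gap to compound 1 both beyond the scatter. Compound 4 `Cc1nn(CC2(O)COC2)cc1Nc1nc(N)c2c(C#N)c(N3CCC[C@H]3C)n(C)c2n1` has not yet been measured; it differs from compound 2 by 3-hydroxyoxetan-3-yl in place of 1-hydroxy-1-methylethyl on a saturated chain carbon bound to an aromatic nitrogen. Within the data shown here, no measured pair isolates this change, so nothing in hand says how the numbers answer it. The step of a 1.3-fold higher number from compound 2 to compound 4 (0.12 log units; within the scatter) is expected to lie within the scatter or only barely beyond it. Compound 4 is estimated at 55 nM, with a range of 20 nM to 150 nM.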

Compound 4, half-maximal inhibitory concentration: 51 nM
Beside the measured number, compound 4's estimate is 1.1-fold (0.03 log units) above it, and the stated range covers the measured number.
By their numbers in this assay, from the lowest: compound 3; then compounds 2 and 4 (each within the scatter of the next); then compound 1.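

In this assay, 3-hydroxyoxetan-3-yl in place of 1-hydroxy-1-methylethyl on a saturated chain carbon bound to an aromatic nitrogen gives a 1.2-fold higher number from compound 2 to compound 4 (0.08 log units; within the scatter), so the two numbers cannot be told apart. For this one pair, this place therefore takes the four-membered ring and its extra oxygen with no step beyond the scatter. Nothing in hand offers an explanation for this result. As far as these compounds go, how an amine, a carboxylic acid or a longer chain would read in this place remains open, as does whether the hydroxy group is needed here.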